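Methylcarbamoyl to ethylcarbamoyl on the core of compound 2

The source may hold more compounds than are shown below. What is called first, only, known or untested is meant among the compounds shown, and "the series" means these compounds.

For the measured compounds named here, in a functional assay on A2780 cells (Homo sapiens) for inhibition (a lower number here means a stronger inhibitor, a higher number a weaker inhibitor), compound 2 `CCNC(=O)c1noc(-c2cc(C(C)C)c(O)cc2O)c1-c1cc(C(=O)NC)no1` gives 100 nM as the only number so far. Compound 1 `CCNC(=O)c1noc(-c2cc(C(C)C)c(O)cc2O)c1-c1cc(COCC(=O)OC)no1` reads "not determined" (no result reported) and offers no comparison. Compound 3 `CCNC(=O)c1cc(-c2c(C(=O)NCC)noc2-c2cc(C(C)C)c(O)cc2O)on1` differs from compound 2 by methyl in place of hydrogen on a saturated chain carbon bound to an amide-type nitrogen with methyl in place of hydrogen on a saturated chain carbon bound to an amide-type nitrogen, methylcarbamoyl to ethylcarbamoyl. Going by the values given here, with compound 2 at 100 nM as the sole anchor and no measured step covering this change, nothing beyond the scatter is expected in this assay here. The estimated 1.3-fold lower number from compound 2 to compound 3 (0.10 log units; within the scatter) is expected to stay small. Compound 3 is expected at 80 nM with an estimated range from 30 nM to 220 nM in this series.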

Compound 3, half-maximal inhibitory concentration: 43 nM
Compound 3: middle estimate off by 1.9-fold (0.27 log units), on the high side; low and high end bracket the measured number.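

In this assay, for the compounds shown here, the change from methylcarbamoyl to ethylcarbamoyl gives a 2.3-fold lower number from compound 2 to compound 3 (0.37 log units; beyond the scatter) and is the first readable step. This position therefore accepts methyl in place of hydrogen on a saturated chain carbon bound to an amide-type nitrogen, with a modest gain beyond the scatter. Nothing available explains the gain.

This rests on a single pair of compounds. As far as these compounds go, whether a longer chain such as propyl, or a carboxylic acid or an amine in this place, would keep or lose the gain remains open.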